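Sulfonyl aziridine in place of acetyl on the shared core

The compounds below may be only part of what the source reports. "The series", "measured", "known", "first", "only" and "open" are said of these compounds alone.

Measured compounds in an assay on HEK293 cells for binding affinity to Neuronal acetylcholine receptor; alpha4/beta2 (Homo sapiens); a higher number here means a weaker inhibitor, a lower number a stronger inhibitor:
- compound 1 `CC(=O)c1ccc2c(c1)C1CNCC2C1`: 0.17 nM
- compound 2 `FC(F)(F)c1cccc2c1C1CNCC2C1`: 39 nM

Compound 1 has the lower of the two numbers in this assay, and the gap to compound 2 is well beyond the scatter of repeat measurements. For the measured compounds named here, compound 2 carries a trifluoromethyl on the shared core instead of an acetyl, and at a different position, so no single-point step between the two measured compounds can be drawn; the two values only show that compound 1 sits far below compound 2.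

Compound 3 `O=S(=O)(c1ccc2c(c1)C1CNCC2C1)N1CC1` is not yet measured. It differs from compound 1 in one place: a group of 6 heavy atoms (2 carbon, 1 nitrogen, 2 oxygen, 1 sulfur; one three-membered non-aromatic ring with 1 hetero atom) in place of a group of 3 heavy atoms (2 carbon, 1 oxygen; no ring), on an aromatic carbon. The acetyl of compound 1 is thus exchanged for a sulfonyl-linked three-membered ring at the same aromatic carbon.

Going by the values given here, with no measured pair that isolates this exchange, the expected step rests on compound 1 alone, which gives 0.17 nM in this assay. The entering group is larger than the one it replaces; a moderate rise in the number, beyond the scatter, is expected rather than a gain. For compound 3 the estimated value in this assay is 1.2 nM, with a likely range from 0.25 nM to 8 nM. The expected step is a 7.1-fold higher number from compound 1 to compound 3 (0.85 log units; beyond the scatter).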

Compound 3, inhibition constant: 2 nM
Estimate against measurement, compound 3: 1.7-fold (0.22 log units) below; measured number inside the range.
By their numbers in this assay, from the lowest: compound 1; then compound 3; then compound 2.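

In this assay, for the compounds shown here, exchanging acetyl for the sulfonyl-linked three-membered ring on this aromatic carbon gives a 12-fold higher number from compound 1 to compound 3 (1.07 log units; beyond the scatter), the first step that isolates a change in one place on the shared core. The step is large and in the unfavourable direction, yet compound 3 still gives 2 nM, so this aromatic carbon can carry a group of 6 heavy atoms with a three-membered ring and 2 hydrogen-bond acceptors without binding being lost altogether. No measurement shown here bears on why the number rises.

The exchange alters the link and the ring together, so the compounds shown do not separate the contribution of the sulfonyl from that of the three-membered ring; a methyl sulfone or an open-chain dimethyl sulfonamide on the same aromatic carbon would bear on that question. From the compounds shown here alone, it also remains open how this position responds to groups of other kinds, such as an amine or a carboxylic acid, and whether any group there matches the acetyl of compound 1.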